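The compounds below may be only part of what the source reports. "The series", "measured", "known", "first", "only" and "open" are said of these compounds alone.

Measured compounds:
Compound 1 `C=CC(=O)N1C(=O)CC(c2ccc(Cl)cc2)Sc2ccccc21`: 95700 nM
Compound 2 `C=CC(=O)N1C(=O)CC(c2cccc(Cl)c2)Sc2ccccc21`: 93100 nM

In a functional assay on HL-60 cells (Homo sapiens) for cytotoxicity, read by CCK-8 assay, with a stated time of 24 h (on this read-out higher numbers stand for weaker inhibition and lower numbers for stronger inhibition), compound 2 gives 93100 nM, level with compound 1 within the scatter. Compound 3 `C=CC(=O)N1C(=O)CC(c2ccc(C#N)cc2)Sc2ccccc21` differs from compound 2 by 4-cyanophenyl in place of 3-chlorophenyl on a saturated ring carbon. For the measured compounds named here, one measured step bears on this change: a 1.0-fold lower number from compound 1 to compound 2 (0.01 log units; within the scatter), which exchanges 4-chlorophenyl for 3-chlorophenyl on the same saturated ring carbon. Going by the values given here, no compound with 4-cyanophenyl has been measured, so the evidence is thin, and no shift beyond the scatter is expected. The expected change is a 1.1-fold lower number from compound 2 to compound 3 (0.04 log units; within the scatter). For compound 3 the estimated value is 85000 nM, with an expected range from 40000 nM to 170000 nM.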

Compound 3, half-maximal inhibitory concentration: 115000 nM
For compound 3 the middle estimate is 1.4-fold (0.13 log units) below the measured one; the measured number falls inside the stated range.
By their numbers in this assay, from the lowest: compounds 2, 1 and 3 (each within the scatter of the next).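

In this assay, the earlier pair only moved the chlorine around the phenyl ring, whereas here the substituent itself is exchanged: 4-cyanophenyl for 3-chlorophenyl gives a 1.2-fold higher number from compound 2 to compound 3 (0.09 log units; within the scatter), and cyano for chloro on the aromatic carbon gives a 1.2-fold higher number from compound 1 to compound 3 (0.08 log units; within the scatter). A nitrile therefore separates itself from neither chlorophenyl compound on this saturated ring carbon next to the ring sulfur. Nothing available explains this level result.

Going by these compounds, whether an amine or a carboxylic acid on the phenyl ring, or a longer alkyl chain in its place, would move the number stays open. So does the part played by the vinylcarbonyl group, which all three compounds carry.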